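A Second Methoxy Group: What to Expect for Compound 4

This account rests on a few compounds, and the source may have more. Where it says the series, first, only, none or still open, it means among the compounds named here.

Measured so far:
Compound 1, `Cc1cccc(-c2cnc(N)nc2-c2ccccc2)c1`, gives 205 nM in an assay on CHO cells for displacement of a labelled ligand from adenosine receptor A1 (Homo sapiens), read by scintillation counting, with a stated time of 1 h; on this read-out higher numbers stand for weaker inhibition and lower numbers for stronger inhibition.
Compound 2, `Nc1ncc(-c2cccc(Cl)c2)c(-c2ccccc2)n1`, gives 55 nM in this assay.
Compound 3, `COc1cccc(-c2cnc(N)nc2-c2ccccc2)c1`, gives 54 nM in this assay.

Compound 3 carries the lowest number of the three, but its nearest neighbour, compound 2, is so close that the two cannot be told apart: a 1.0-fold lower number from compound 2 to compound 3 (0.01 log units; within the scatter). The gap to compound 1 is real, though: a 3.8-fold lower number from compound 1 to compound 3 (0.58 log units; beyond the scatter).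

Compound 4, `COc1ccc(-c2cnc(N)nc2-c2ccccc2)cc1OC`, has not yet been measured. It differs from compound 3 in one place: methoxy in place of hydrogen on an aromatic carbon.

Among the measured compounds shown here, no measured step adds a group to a bare position; the two steps that end at compound 3 swap one group for another on the same ring carbon, a 3.8-fold lower number from compound 1 to compound 3 (0.58 log units; beyond the scatter) and a 1.0-fold lower number from compound 2 to compound 3 (0.01 log units; within the scatter). They show that a methoxy group on this ring is at least as good as chloro, but they say nothing about a second methoxy group entering where compound 3 has hydrogen. With that precedent missing, the safest expectation for compound 4 in this assay is a step no larger than the scatter, a 1.1-fold higher number from compound 3 to compound 4 (0.05 log units; within the scatter), in either direction.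

Compound 4 is therefore estimated at 60 nM, with a likely range from 25 nM to 150 nM.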

Compound 4, inhibition constant: 104 nM
Compound 4: middle estimate off by 1.7-fold (0.24 log units), on the low side; the measured number falls inside the stated range.
By their numbers in this assay, from the lowest: compounds 3, 2, 4 and 1 (each within the scatter of the next, the first and the last beyond it).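

Compound 4 gives the first measured case in this series of a group entering where the ring carried only hydrogen: a methoxy group ortho to a methoxy group and para to a large group. In this assay, this change gives a 1.9-fold higher number from compound 3 to compound 4 (0.28 log units; within the scatter), so compound 3 and compound 4 cannot be told apart, and this carbon can carry a second methoxy group without a difference that the measurement can resolve, something the earlier swaps among methyl, chloro and methoxy on another ring carbon could not show. No separate measurement is available to explain the size of this step.

The compounds shown leave open whether this tolerance belongs to methoxy alone or extends to other groups on the same carbon, such as an amine, a carboxylic acid or a longer chain like butoxy. They also leave open how a methoxy group on this carbon would read in the absence of the methoxy group already present in compound 3.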